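Methoxy for carboxy on the aniline: forecasting compound 4

The source may hold more compounds than are shown below. What is called first, only, known or untested is meant among the compounds shown, and "the series" means these compounds.

Measured compounds:
compound 1 `C=C1[C@@H](OC(C)=O)C[C@@H]2[C@](C)(COC=O)[C@H](OC(C)=O)CC[C@@]2(C)[C@@H]1C[C@@H](Nc1ccc(OC)cc1)C1=CCOC1=O` gives 25400 nM
compound 2 `C=C1[C@@H](OC(C)=O)C[C@@H]2[C@](C)(CO[Si](C)(C)C(C)(C)C)[C@H](OC(C)=O)CC[C@@]2(C)[C@@H]1C[C@@H](Nc1ccc(C(=O)O)cc1)C1=CCOC1=O` gives 4630 nM
compound 3 `C=C1[C@@H](OC(C)=O)C[C@@H]2[C@](C)(COC=O)[C@H](OC(C)=O)CC[C@@]2(C)[C@@H]1C[C@@H](Nc1ccc(C(=O)O)cc1)C1=CCOC1=O` gives 37200 nM

In a functional assay on HT-29 cells (Homo sapiens) for cytotoxicity, read by sulforhodamine B assay (a higher number here means a weaker inhibitor, a lower number a stronger inhibitor), compound 2 stands lowest of the three, and compound 3 reaches it through an 8.0-fold higher number from compound 2 to compound 3 (0.90 log units; beyond the scatter); the two cores differ by a group of 7 heavy atoms (6 carbon, 1 silicon; no ring) in place of a group of 2 heavy atoms (1 carbon, 1 oxygen; no ring), on an oxygen on a saturated carbon. Compound 4 `C=C1[C@@H](OC(C)=O)C[C@@H]2[C@](C)(CO[Si](C)(C)C(C)(C)C)[C@H](OC(C)=O)CC[C@@]2(C)[C@@H]1C[C@@H](Nc1ccc(OC)cc1)C1=CCOC1=O` is not yet measured. It differs from compound 2 by methoxy in place of carboxy on an aromatic carbon. The same change is seen between compound 3 and compound 1, (methoxy in place of carboxy on an aromatic carbon), where it gave a 1.5-fold lower number from compound 3 to compound 1 (0.17 log units; within the scatter). Since the change at the aromatic carbon is identical in both pairs, the step from compound 2 to compound 4 is expected to be about as small, a 1.4-fold lower number from compound 2 to compound 4 (0.15 log units; within the scatter), resting on compound 1 and compound 3 and on the value of compound 2 in this assay. Compound 4 is therefore estimated at 3300 nM, likely between 1400 nM and 8000 nM.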

Compound 4, half-maximal inhibitory concentration: 5370 nM
For compound 4 the middle estimate is 1.6-fold (0.21 log units) below the measured one; measured number inside the range.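

In this assay, methoxy in place of carboxy on an aromatic carbon gave a 1.2-fold higher number from compound 2 to compound 4 (0.06 log units; within the scatter), and this agrees with the same change on the other core: the same change on two cores in this assay, a 1.5-fold lower number (0.17 log units; within the scatter) from compound 3 to compound 1 and a 1.2-fold higher number (0.06 log units; within the scatter) from compound 2 to compound 4, 1.7-fold (0.23 log units) apart, within the scatter of two such steps. The larger exchange on the oxygen on a saturated carbon also carried over, with a 4.7-fold lower number from compound 1 to compound 4 (0.67 log units; beyond the scatter), matching the earlier step: the same change on two cores in this assay, an 8.0-fold higher number (0.90 log units; beyond the scatter) from compound 2 to compound 3 and a 4.7-fold higher number (0.67 log units; beyond the scatter) from compound 4 to compound 1, 1.7-fold (0.23 log units) apart, within the scatter of two such steps. Together these show that both changes kept their size across these two cores in this one assay, but they do not show that this would hold for other cores or other groups.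

The compounds shown leave open whether an amine or a chlorine on the same aromatic carbon would carry over in the same way. They also leave open how a free hydroxyl would compare on that oxygen.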